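A few compounds are considered here, and "the series" means these few. Any claim that something is new, unique, unknown or untested is made for them only; others in the source may bear on it.

Working notes on the series. Compound 1, `Cc1ncc(-c2ccccc2NCC2=NCCN2)o1`, and compound 2, `Cc1nc(-c2ccccc2NCC2=NCCN2)co1`, share a core and differ only in the five-membered ring on an aromatic carbon. In a functional assay for activation of Alpha-1D adrenergic receptor (Homo sapiens) (a higher number here means that more compound is needed for the effect, a lower number that less compound is needed), compound 1 gives < 5020 nM, which is a limit of the assay and not a number. In this assay compound 2 likewise gives < 5020 nM, again a limit and not a number. The step that the two limits leave unreadable from compound 1 to compound 2 therefore has no readable size. Where compound 2 stands is thus known only as a limit, and the evidence so far is summed up by the limit of < 5020 nM in this assay, at which 2 of the 2 values shown sit.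

Compound 3, `Cc1cc(-c2ccccc2NCC2=NCCN2)on1`, is not yet measured. Its change from compound 2 is 3-methyl-1,2-oxazol-5-yl in place of 2-methyl-1,3-oxazol-4-yl on an aromatic carbon. Among the compounds with values here, the one measured step, from compound 1 to compound 2, bears on it only in that a rearrangement of the same five-membered ring left the value on the same side of the limit both times; its size is unreadable. Within the data shown here, no step of readable size is available, so the expected step that the limit leaves unreadable from compound 2 to compound 3 is none beyond the scatter. Compound 3 is estimated at 1200 nM in this assay, with a range from 150 nM to 5020 nM.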

Compound 3, half-maximal effective concentration: < 100000 nM
Compound 3 ended at the assay's limit (the forecaster's own chance of this, stated with the estimate: 65%); the middle value does not contradict the limit.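

Within the data shown here, compound 1, compound 2 and compound 3 all stand as limits of the assay in this assay, not as numbers, so no step among them can be read. The compounds shown leave open whether 2-methyl-1,3-oxazol-5-yl, 2-methyl-1,3-oxazol-4-yl and 3-methyl-1,2-oxazol-5-yl differ at all in this assay, and by how much.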